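A few compounds are considered here, and "the series" means these few. Any claim that something is new, unique, unknown or untested is made for them only; others in the source may bear on it.

Compound 3, with the structure `CC(C)(C)c1nc(CCCCCC#N)c2c(N)c(C#N)c(N)nc2n1`, is measured in a physicochemical assay for solubility, in phosphate buffer, with a stated time of 18 h (on this read-out lower numbers stand for lower solubility and higher numbers for higher solubility), where it gives 6000 nM. That is the lowest of the three numbers in hand. Compound 1, with the structure `CC(C)(C)c1ccc2c(N)c(C#N)c(N)nc2n1`, gives 14200 nM in this assay, the nearest of the other two values and beyond the scatter from compound 3. Compound 2, with the structure `N#Cc1c(N)nc2nc(C3CC3)ncc2c1N`, gives 23000 nM in this assay, the furthest away and likewise beyond the scatter from compound 3. Among the measured compounds shown here, none of these three compounds differs from another in a single place, so no measured step isolates any one change.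

Compound 4, with the structure `CC(C)(C)c1nc(-c2ncc[nH]2)c2c(N)c(C#N)c(N)nc2n1`, has not yet been measured in this assay. It differs from compound 3 in one place: 1H-imidazol-2-yl in place of 5-cyanopentyl on an aromatic carbon. For the measured compounds named here, since no measured pair here shows what this change does, only an expectation can be given. For compound 4 in this assay the expected value is 8000 nM, within a range from 2500 nM to 25000 nM. That estimate means a step from compound 3 to compound 4 of a 1.3-fold higher number from compound 3 to compound 4 (0.12 log units; within the scatter), which is expected to stay within the scatter.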

Compound 4, solubility: < 1000 nM
Compound 4 was reported as a limit; the forecaster's own chance of this, stated with the estimate: 10%; middle value at least 8.0-fold (0.90 log units) from the limit.
By their numbers in this assay, from the lowest: compound 3; then compounds 1 and 2 (each within the scatter of the next). At a limit, below all of these: compound 4.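

Among the compounds shown here, until this result no measured pair showed what a change at this position does. On this aromatic carbon, next to the ring nitrogen, 1H-imidazol-2-yl in place of 5-cyanopentyl gives an at least 6.0-fold lower number from compound 3 to compound 4 (0.77 log units; beyond the scatter) in this assay, so this read-out is sensitive to the group held here, at least for this exchange of an open chain for a five-membered aromatic ring with a hydrogen-bond donor. The value of compound 4 is a limit and not a number: the limit of < 1000 nM in this assay, at which 1 of the 4 values shown sits.

This single step cannot separate the loss of the 5-cyanopentyl chain from the arrival of the ring or of its donor. From the compounds shown here alone, it remains open whether a phenyl ring, an amine or a shorter carbon chain in this place would read like compound 3 or like compound 4.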